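Naphthyl to Fluorophenyl: Expected Return of Cytotoxicity

The source may report more compounds than this note shows. Statements on the series, on what has been measured and on what is new or still open speak of the compounds shown alone.

In an ADME assay on MT4 cells (Homo sapiens) for cytotoxicity, read by MTT assay, with a stated time of 5 days (on this read-out lower numbers stand for higher toxicity in this test and higher numbers for lower toxicity in this test), compound 1 `Cc1cc(C#N)cc(C)c1Oc1nc(Nc2ccc(C#N)cc2)ncc1-c1ccccc1` gives 31800 nM and compound 2 `Cc1cc(C#N)cc(C)c1Oc1nc(Nc2ccc(C#N)cc2)ncc1-c1ccc(Cl)cc1` gives 72600 nM. Compound 3 `Cc1cc(C#N)cc(C)c1Oc1nc(Nc2ccc(C#N)cc2)ncc1-c1cccc2ccccc12` reaches only the limit of this assay, > 267000 nM, so its value is known as a limit and not as a number, and it stands at the top of the three. Compound 4 `Cc1cc(C#N)cc(C)c1Oc1nc(Nc2ccc(C#N)cc2)ncc1-c1ccc(F)cc1` differs from it by 4-fluorophenyl in place of naphthalen-1-yl on an aromatic carbon. This change runs against the measured steps of an at least 8.3-fold higher number from compound 1 to compound 3 (0.92 log units; beyond the scatter) and an at least 3.6-fold higher number from compound 2 to compound 3 (0.56 log units; beyond the scatter), so a lower number is expected, toward the values of compound 1 and compound 2. The estimated step is an at least 6.6-fold lower number from compound 3 to compound 4 (0.82 log units; beyond the scatter), giving an expected value for compound 4 of 40000 nM, in the range 15000 nM to 110000 nM.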

Compound 4, half-maximal cytotoxic concentration: 42700 nM
For compound 4 the middle estimate is 1.1-fold (0.03 log units) below the measured one; measured number inside the range.
By their numbers in this assay, from the lowest: compounds 1, 4 and 2 (each within the scatter of the next, the first and the last beyond it). At a limit, above all of these: compound 3.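

In this assay, an at least 6.2-fold lower number from compound 3 to compound 4 (0.79 log units; beyond the scatter) shows that 4-fluorophenyl on this aromatic carbon does not hold the number reached with naphthalen-1-yl, and this step is only a bound: the limit of > 267000 nM in this assay, at which 1 of the 4 values shown sits.

Fluoro in place of hydrogen gives a 1.3-fold higher number from compound 1 to compound 4 (0.13 log units; within the scatter), and fluoro in place of chloro gives a 1.7-fold lower number from compound 2 to compound 4 (0.23 log units; within the scatter); both lie within the scatter, so among the four only the naphthalen-1-yl group stands apart from the others.

The compounds shown leave open what a naphthalen-2-yl group, or an amine or a carboxylic acid on the phenyl ring, would give in this assay.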